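The source may report more compounds than this note shows. Statements on the series, on what has been measured and on what is new or still open speak of the compounds shown alone.

Three measured compounds share the same core and differ only in the thioether chain and in the hydrazone arm. In a functional assay on ECa-109 cells (Homo sapiens) for antiproliferative activity, read by MTT assay, with a stated time of 72 h (on this read-out higher numbers stand for weaker inhibition and lower numbers for stronger inhibition), compound 1 `CCCSc1nc(N/N=C/c2cc(OC)c(OC)c(OC)c2)c2nnn(Cc3ccccc3)c2n1` gives 4060 nM. Compound 2 `CCCSc1nc(N/N=C/c2ccc(N(C)C)cc2)c2nnn(Cc3ccccc3)c2n1` gives 20000 nM in this assay. Compound 3 `C#CCSc1nc(N/N=C(\C)c2ccccc2O)c2nnn(Cc3ccccc3)c2n1` gives 5250 nM in this assay. Compound 1 thus carries the lowest number of the three; its gap to compound 3 lies within the scatter of the method, while compound 2 sits beyond it. No two of these compounds differ in a single place, so no isolated step is available.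

Compound 4 `C#CCSc1nc(N/N=C/c2cc(OC)c(OC)c(OC)c2)c2nnn(Cc3ccccc3)c2n1` has not yet been measured. From compound 1 it differs by ethynyl in place of ethyl on a saturated chain carbon bound to a sulfur. Compound 3 already carries the propargylsulfanyl chain and gives a number close to that of compound 1, but its hydrazone arm also differs, so this says little about the chain on its own. The expected step is a 1.1-fold higher number from compound 1 to compound 4 (0.04 log units; within the scatter), in no direction beyond the scatter. Compound 4 is expected to give 4500 nM in this assay, with a range from 1500 nM to 13000 nM.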

Compound 4, half-maximal inhibitory concentration: 6540 nM
Compound 4: the middle estimate sits 1.5-fold (0.16 log units) below what was measured, and the stated range covers the measured number.
By their numbers in this assay, from the lowest: compounds 1, 3 and 4 (each within the scatter of the next); then compound 2.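

With the hydrazone arm held constant, propylsulfanyl to propargylsulfanyl can now be read on its own, and this assay gives a 1.6-fold higher number from compound 1 to compound 4 (0.21 log units; within the scatter). For this arm, then, ethynyl in place of ethyl on a saturated chain carbon bound to a sulfur leaves the number within the scatter, something the pair of compound 1 and compound 3 could not show with their different arms. No measured property bears on this step, so it stays a bare observation.

Going by these compounds, whether the same change gives a similar step on the hydrazone arms of compound 2 and compound 3 remains open. Also open, on these data alone, is how a longer chain, or a chain ending in an amine or a carboxylic acid, would read in this assay.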